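A few compounds are considered here, and "the series" means these few. Any claim that something is new, unique, unknown or untested is made for them only; others in the source may bear on it.

Measured compounds:
- compound 1 `CC(c1ccc(-c2ccccc2)c(F)c1)c1nnc2n1N=C(c1ccc(OC(F)(F)F)cc1)CS2`, in a functional assay on HCT-116 cells (Homo sapiens) for inhibition, read by sulforhodamine B assay, with a stated time of 72 h (on this read-out higher numbers stand for weaker inhibition and lower numbers for stronger inhibition), compound 1 gives 5400 nM
- compound 2 `CC(c1ccc(-c2ccccc2)c(F)c1)c1nnc2n1N=C(c1ccc(Br)cc1)CS2`, in this assay compound 2 gives 7100 nM
- compound 3 `Cc1ccc(C2=Nn3c(nnc3C(C)c3ccc(-c4ccccc4)c(F)c3)SC2)cc1`, in this assay compound 3 gives 4800 nM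

Compound 3 carries the lowest of the three numbers, but its steps to the others are small: a 1.1-fold lower number from compound 1 to compound 3 (0.05 log units; within the scatter) and a 1.5-fold lower number from compound 2 to compound 3 (0.17 log units; within the scatter), both within the scatter, so the three compounds cannot be ranked against one another. The step from compound 1 to compound 2 is likewise small: a 1.3-fold higher number from compound 1 to compound 2 (0.12 log units; within the scatter).

Compound 4 `CC(c1ccc(-c2ccccc2)c(F)c1)c1nnc2n1N=C(c1ccc([N+](=O)[O-])cc1)CS2` differs from compound 3 by nitro in place of methyl on an aromatic carbon. The change sits at the same aromatic carbon that was varied in all three measured steps, and none of those steps moved the number beyond the scatter. On that basis the author expects no step beyond the scatter in this assay for compound 4, with the expected step being a 1.1-fold higher number from compound 3 to compound 4 (0.06 log units; within the scatter). The estimate for compound 4 is therefore 5500 nM, with a range from 2500 nM to 12000 nM.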

Compound 4, half-maximal inhibitory concentration: 7100 nM
Compound 4: the middle estimate sits 1.3-fold (0.11 log units) below what was measured; measured number inside the range.
By their numbers in this assay, from the lowest: compounds 3, 1, 2 and 4 (each within the scatter of the next).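

In this assay, the 4-nitrophenyl group of compound 4 stays within the scatter of all three earlier compounds (a 1.5-fold higher number from compound 3 to compound 4 (0.17 log units; within the scatter)) (no change at the digits printed from compound 2 to compound 4 (within the scatter)) (a 1.3-fold higher number from compound 1 to compound 4 (0.12 log units; within the scatter)). Nitro thus becomes a fourth group at this aromatic carbon, and it brings hydrogen-bond acceptors where methyl brings none, yet no step among the four compounds goes beyond the scatter, so they still cannot be ranked. Nothing available explains why the number holds across these groups.

The compounds shown leave open whether an amine or a carboxylic acid at this carbon would move the number beyond the scatter. They also leave open whether changes elsewhere on the shared core would do so.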